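A few compounds are considered here, and "the series" means these few. Any claim that something is new, unique, unknown or untested is made for them only; others in the source may bear on it.

Measured so far:
compound 1 `CCOC(=O)C1=C(N/N=C(/C#N)C(=O)OCC)Nc2[nH]nc(C)c2C1c1ccc(N(C)C)cc1`: 46400 nM
compound 2 `CCOC(=O)C1=C(N/N=C(\C#N)C(N)=O)Nc2[nH]nc(C)c2C1c1ccc(N(C)C)cc1`: 48400 nM
compound 3 `CCOC(=O)C1=C(N/C=N/c2ccccn2)Nc2[nH]nc(C)c2C1c1ccc(N(C)C)cc1`: 26200 nM

These values come from a functional assay on HepG2 cells (Homo sapiens) for inhibition, read by MTT assay, with a stated time of 48 h; on this read-out lower numbers stand for stronger inhibition and higher numbers for weaker inhibition. The three compounds share one core and differ only in the group on an amine nitrogen. Compound 3 holds the lowest number of the three, but it lies within the scatter of both others: a 1.8-fold lower number from compound 1 to compound 3 (0.25 log units; within the scatter) and a 1.8-fold lower number from compound 2 to compound 3 (0.27 log units; within the scatter). The remaining pair gives a 1.0-fold higher number from compound 1 to compound 2 (0.02 log units; within the scatter).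

Compound 4 `CCOC(=O)C1=C(N)Nc2[nH]nc(C)c2C1c1ccc(N(C)C)cc1` has not yet been measured. Its structure differs from that of compound 3 by a hydrogen atom in place of a group of 8 heavy atoms (6 carbon, 2 nitrogen; one six-membered aromatic ring with 1 hetero atom), on an amine nitrogen. Among the compounds with values here, the three measured steps are the only guide, and each swaps one group on that nitrogen for another, all within the scatter. None of them shows what happens with only hydrogen there, so they bear on this step only in part, and the range must stay wide.

Among the measured compounds, those without a ring in this group are compound 1 at 46400 nM and compound 2 at 48400 nM. A small move towards those numbers, not beyond the scatter, therefore seems the best guess. The expected step is a 1.5-fold higher number from compound 3 to compound 4 (0.18 log units; within the scatter). Compound 4 is estimated at 40000 nM, with an expected range from 18000 nM to 90000 nM.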

Compound 4, half-maximal inhibitory concentration: 4240 nM
Compound 4: the middle estimate sits 9.4-fold (0.97 log units) above what was measured, and the stated range ends above it.
By their numbers in this assay, from the lowest: compound 4; then compounds 3, 1 and 2 (each within the scatter of the next).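

The earlier compounds shown here only traded one sizeable group on this amine nitrogen for another, and their numbers stayed within the scatter of one another, so they could not show whether having such a group there matters at all. In this assay, the free amine, with a hydrogen atom on that nitrogen, gives a clear drop against each of the three substituted compounds (a 6.2-fold lower number from compound 3 to compound 4 (0.79 log units; beyond the scatter); an 11-fold lower number from compound 2 to compound 4 (1.06 log units; beyond the scatter); an 11-fold lower number from compound 1 to compound 4 (1.04 log units; beyond the scatter)), so all three groups, with or without a ring, go with weaker inhibition than hydrogen, and no compound shown goes against this. Nothing measured here explains the difference.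

The compounds shown jump straight from hydrogen to these sizeable groups, so it remains open whether a small group such as methyl or acetyl would keep the lower number or already lose it. It also remains open whether a group carrying its own amine or a carboxylic acid on this nitrogen would follow the same pattern as the three groups shown.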